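Working notes: phenoxy to dimethylamino in a cell assay

A few compounds are considered here, and "the series" means these few. Any claim that something is new, unique, unknown or untested is made for them only; others in the source may bear on it.

Two compounds of the series have been run in a functional assay on A498 cells (Homo sapiens) for inhibition, read by sulforhodamine B assay, with a stated time of 48 h; a higher number here means that more compound is tolerated, a lower number that less compound is tolerated. Compound 1 `COc1cc(C)cc(-c2nn(CC#N)cc2-c2ccc(-c3cccc(C(C)=O)c3)nc2)c1` gives 72500 nM in this assay. Compound 2 `Cc1cc(O)cc(-c2nn(CC#N)cc2-c2ccnc(-c3ccc(Oc4ccccc4)cc3)c2)c1` gives 44100 nM in this assay, the lowest of the two numbers, with compound 1 above it by a gap that lies within the usual scatter, so no order between the two can be claimed. Compound 3 `Cc1cc(O)cc(-c2nn(CC#N)cc2-c2ccnc(-c3ccc(N(C)C)cc3)c2)c1` is not yet measured. It carries dimethylamino in place of phenoxy on an aromatic carbon, dimethylamino in place of phenoxy on an aromatic carbon. For the measured compounds named here, no pair of measured compounds shows this change, so the step has no precedent. In this assay a step of modest size and no clear direction is expected, probably not beyond the scatter. For compound 3 the estimate in this assay is 50000 nM, with a range from 20000 nM to 120000 nM, which means an expected step of a 1.1-fold higher number from compound 2 to compound 3 (0.05 log units; within the scatter).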

Compound 3, concentration lethal to 50% of the cells: > 100000 nM
Compound 3 ended at the assay's limit (the forecaster's own chance of this, stated with the estimate: 15%); middle value at least 2.0-fold (0.30 log units) away from the limit.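

In this assay, the place para to a large group now has its first single-change step, and the change from phenoxy to dimethylamino moves the result beyond the scatter: an at least 2.2-fold higher number from compound 2 to compound 3 (0.35 log units; beyond the scatter). Compound 3 gives > 100000 nM, which is a limit of the assay and not a number. The size of the step can therefore be read in one direction only, with its upper end unknown: the limit of > 100000 nM in this assay, at which 1 of the 3 values shown sits.

As far as these compounds go, with a single step, it remains open whether the higher number goes with the departure of the phenoxy group and its aromatic ring or with the arrival of dimethylamino. A methoxy group or a benzyloxy group at the same place, on the core of compound 2, would help to separate these two readings.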